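A few compounds are considered here, and "the series" means these few. Any claim that something is new, unique, unknown or untested is made for them only; others in the source may bear on it.

Measured in a functional assay for inhibition; a lower number here means a stronger inhibitor, a higher number a weaker inhibitor:

- compound 1 `CC(C)(C)c1cc(-c2cc(=O)c3ccc(OCc4ccc(Cl)cc4)cc3o2)cc(C(C)(C)C)c1O`: 7000 nM
- compound 2 `CC(C)(C)c1cc(-c2cc(=O)c3ccc(OCC(=O)N4CCCCC4)cc3o2)cc(C(C)(C)C)c1O`: 3000 nM
- compound 3 `CCN(CC)C(=O)COc1ccc2c(=O)cc(-c3cc(C(C)(C)C)c(O)c(C(C)(C)C)c3)oc2c1`: 3000 nM

Compound 3 stands level with compound 2, and the two share the lowest of the three numbers. The next compound, compound 4 `CCOC(=O)CCCCOc1ccc2c(=O)cc(-c3cc(C(C)(C)C)c(O)c(C(C)(C)C)c3)oc2c1`, keeps the shared core but carries 3-(ethoxycarbonyl)propyl in place of diethylcarbamoyl on a saturated chain carbon bound to an oxygen on an aromatic ring. Neither group contains a ring, and neither carries a net charge.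

Three measured steps offer some guidance. Two changes at this same place were modest: a 2.3-fold lower number from compound 1 to compound 2 (0.37 log units; beyond the scatter) and a 2.3-fold lower number from compound 1 to compound 3 (0.37 log units; beyond the scatter). Exchanging one amine part for another gave no change at the digits printed from compound 2 to compound 3 (within the scatter). Going by the values given here, none of the measured compounds has an ester, so this evidence is indirect. With only modest steps seen at this place, a small move towards a weaker number is expected, not a large one. The expected step is a 1.3-fold higher number from compound 3 to compound 4 (0.12 log units; within the scatter). For compound 4 the estimated value is 4000 nM, with an expected range from 1500 nM to 10000 nM.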

Compound 4, half-maximal inhibitory concentration: 3000 nM
Compound 4: middle estimate off by 1.3-fold (0.12 log units), on the high side; the measured number falls inside the stated range.
By their numbers in this assay, from the lowest: compounds 2, 3 and 4 (each within the scatter of the next); then compound 1.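

In this assay, compound 4 replaces the amide end group with an ester on a longer chain, giving no change at the digits printed from compound 3 to compound 4 (within the scatter) and no change at the digits printed from compound 2 to compound 4 (within the scatter), so among these compounds an amide nitrogen is not needed at this place to reach this level. The step of a 2.3-fold lower number from compound 1 to compound 4 (0.37 log units; beyond the scatter) places compound 4 with the two amides, leaving compound 1, the only one of the four without a carbonyl in this group, apart from the rest. Nothing measured here explains why such different groups read alike.

Chain length and end group differ together in compound 4, so their separate contributions remain unknown. Also open, as far as these compounds go, is how a free carboxylic acid in place of the ethyl ester, or a plain hexyl chain without any carbonyl, would read.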